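The source may hold more compounds than are shown below. What is called first, only, known or untested is meant among the compounds shown, and "the series" means these compounds.

Measured in a functional assay on K562 cells (Homo sapiens) for antiproliferative activity, read by MTT assay, with a stated time of 48 h; a higher number here means a weaker inhibitor, a lower number a stronger inhibitor:
compound 1 `CN(C)CCCn1c(N)c(-c2nc3ccccc3[nH]2)c2nc(C#N)c(C#N)nc21` gives 1730 nM
compound 2 `CCN(CC)CCCn1c(N)c(-c2nc3ccccc3[nH]2)c2nc(C#N)c(C#N)nc21` gives 1800 nM
compound 3 `CN(C)CCCn1c(N)c(-c2nc3ccccc3n2C)c2nc(C#N)c(C#N)nc21` gives 3560 nM

Compound 2 differs from compound 1 by diethylamino in place of dimethylamino on a saturated chain carbon, three bonds along the chain from an aromatic nitrogen, and in this assay this produced a 1.0-fold higher number from compound 1 to compound 2 (0.02 log units; within the scatter). Compound 3 differs from compound 1 by methyl in place of hydrogen on an aromatic nitrogen, which gave a 2.1-fold higher number from compound 1 to compound 3 (0.31 log units; beyond the scatter). Compound 4 `CCN(CC)CCCn1c(N)c(-c2nc3ccccc3n2C)c2nc(C#N)c(C#N)nc21` carries both changes: it differs from compound 3 by diethylamino in place of dimethylamino on a saturated chain carbon, three bonds along the chain from an aromatic nitrogen, the same change that separates compound 2 from compound 1, made at the same place on the core of compound 3. Among the compounds with values here, with only one earlier instance to go on, the expectation for compound 4 rests on compound 1 and compound 2, whose step a 1.0-fold higher number from compound 1 to compound 2 (0.02 log units; within the scatter) was flat, so an expected 1.0-fold higher number from compound 3 to compound 4 (0.00 log units; within the scatter) follows. Compound 4 is therefore expected to give about 3600 nM in this assay, estimated to fall between 1800 nM and 7200 nM.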

Compound 4, half-maximal inhibitory concentration: 3270 nM
For compound 4 the middle estimate is 1.1-fold (0.04 log units) above the measured one, and the stated range covers the measured number.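

In this assay, diethylamino in place of dimethylamino is also flat on the core of compound 3, with a 1.1-fold lower number from compound 3 to compound 4 (0.04 log units; within the scatter), and the two cores agree on this change: the same change on two cores in this assay, a 1.0-fold higher number (0.02 log units; within the scatter) from compound 1 to compound 2 and a 1.1-fold lower number (0.04 log units; within the scatter) from compound 3 to compound 4, 1.1-fold (0.05 log units) apart, within the scatter of two such steps. For methyl in place of hydrogen on an aromatic nitrogen, the step on the diethylamino side reads a 1.8-fold higher number from compound 2 to compound 4 (0.26 log units; within the scatter), and it too agrees with the earlier step: the same change on two cores in this assay, a 2.1-fold higher number (0.31 log units; beyond the scatter) from compound 1 to compound 3 and a 1.8-fold higher number (0.26 log units; within the scatter) from compound 2 to compound 4, 1.1-fold (0.05 log units) apart, within the scatter of two such steps. Each change thus carried over between the two cores shown, but these four compounds alone do not show that it would carry to any other core.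

From the compounds shown here alone, it remains open whether a primary amine or a longer chain would be equally flat. Also open, going by these compounds, is how an ethyl group on that aromatic nitrogen, or another group in place of the nitriles, would read.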